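Shortening the hydroxycarbamoyl chain of compound 2

The source may report more compounds than this note shows. Statements on the series, on what has been measured and on what is new or still open speak of the compounds shown alone.

Values measured in a functional assay on HCT-116 cells (Homo sapiens) for inhibition, read by MTT assay, with a stated time of 72 h (a lower number here means a stronger inhibitor, a higher number a weaker inhibitor), follow
- Compound 1 `CNC(=O)CCCCCCCn1nc(-c2cnc3[nH]ccc3c2)c2c(N)ncnc21` gives 6760 nM
- Compound 2 `Nc1nc2cc(-c3nn(CCCC(=O)NO)c4ncnc(N)c34)ccc2o1` gives 19600 nM

Compound 2 has the higher of the two numbers, so it is the weaker inhibitor, and its gap to compound 1 lies beyond the usual scatter. Compound 3 `Nc1nc2cc(-c3nn(CCC(=O)NO)c4ncnc(N)c34)ccc2o1` has a shorter chain: the change (hydroxycarbamoyl in place of (hydroxycarbamoyl)methyl on a saturated chain carbon, two bonds along the chain from an aromatic nitrogen) puts hydroxycarbamoyl in place of (hydroxycarbamoyl)methyl on a saturated chain carbon, two bonds along the chain from an aromatic nitrogen. Going by the values given here, no measured pair shows the effect of this change, so only a small shift towards weaker inhibition in this assay is expected, possibly none beyond the scatter. The estimate means a 1.3-fold higher number from compound 2 to compound 3 (0.11 log units; within the scatter) as the expected step. Compound 3 is expected to give 25000 nM (estimated range 8000 nM to 80000 nM).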

Compound 3, half-maximal inhibitory concentration: > 100000 nM
Compound 3: no number, only a limit; the forecaster's own chance of this, stated with the estimate: 15%; middle value at least 4.0-fold (0.60 log units) away from the limit.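

Shortening 3-(hydroxycarbamoyl)propyl to 2-(hydroxycarbamoyl)ethyl is not a neutral change: in this assay it gives an at least 5.1-fold higher number from compound 2 to compound 3 (0.70 log units; beyond the scatter). Going by these compounds alone, this is the first sign that chain length at this position matters, as the earlier compounds offered no pair to show it. Compound 3 gives only a limit of the assay, not a number: the limit of > 100000 nM in this assay, at which 1 of the 3 values shown sits.

On these data alone, it remains open whether a longer chain on the core of compound 2 would give a lower number. As far as these compounds go, it also remains open how a carboxylic acid in place of the hydroxycarbamoyl end would compare.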